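A few compounds are considered here, and "the series" means these few. Any claim that something is new, unique, unknown or untested is made for them only; others in the source may bear on it.

Compound 2 `CC1(C#Cc2c(Cl)c3c(Cl)cc(C(N)=O)nc3n2[C@H]2CCCNC2)COC1` gives the lower of the two numbers recorded in a functional assay on KG-1 cells (Homo sapiens) for antiproliferative activity (on this read-out lower numbers stand for an effect already at smaller amounts and higher numbers for an effect only at larger amounts of compound), where compound 2 gives 119 nM. Among the compounds with values here, its only neighbour is compound 1 `COCC(C)(C)C#Cc1c(Cl)c2c(Cl)cc(C(N)=O)nc2n1[C@H]1CCCNC1`, which in this assay gives 219 nM; the step of a 1.8-fold lower number from compound 1 to compound 2 (0.26 log units; within the scatter) is the sole measured comparison, and it does not rise above the scatter. Compound 3 `NC(=O)c1cc(Cl)c2c(Cl)c(C#CCCO)n([C@H]3CCCNC3)c2n1` is the next member of the series, differing from compound 2 by 2-hydroxyethyl in place of 3-methyloxetan-3-yl on a triple-bonded carbon. Within the data shown here, the one measured step on this same triple-bonded carbon, a 1.8-fold lower number from compound 1 to compound 2 (0.26 log units; within the scatter), exchanged two groups at that position without a change beyond the scatter, so the replacement in compound 3 is expected to behave alike in this assay. For compound 3 the step of a 1.3-fold higher number from compound 2 to compound 3 (0.13 log units; within the scatter) is therefore estimated to stay within the scatter. Compound 3 is accordingly expected to give about 160 nM, with a plausible range from 65 nM to 400 nM.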

Compound 3, half-maximal effective concentration: 56 nM
Beside the measured number, compound 3's estimate is 2.9-fold (0.46 log units) above it; the whole stated range lies above it.
By their numbers in this assay, from the lowest: compound 3; then compounds 2 and 1 (each within the scatter of the next).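

In this assay, changing the group on this triple-bonded carbon now moves the number beyond the scatter: 2-hydroxyethyl in place of 3-methyloxetan-3-yl gives a 2.1-fold lower number from compound 2 to compound 3 (0.33 log units; beyond the scatter), and 2-hydroxyethyl in place of 1-(methoxymethyl)-1-methylethyl gives a 3.9-fold lower number from compound 1 to compound 3 (0.59 log units; beyond the scatter), both modest in size. The only earlier step, a 1.8-fold lower number from compound 1 to compound 2 (0.26 log units; within the scatter), had shown no change that could be told from the scatter, so this position is now seen to respond to the group it carries. Nothing available ties the shift to any one difference between the groups, such as the hydrogen-bond donor that enters or the ring that leaves.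

On these data alone, how a 2-methoxyethyl group, a 2-aminoethyl group or a longer 3-hydroxypropyl chain would read on the same carbon remains open. Also open, as far as these compounds go, is how a 3-hydroxyoxetan-3-yl group, which holds a ring and a hydroxyl together, would compare.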